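Two amines on one thiocarbonyl carbon, one result pending

This account rests on a few compounds, and the source may have more. Where it says the series, first, only, none or still open, it means among the compounds named here.

Compound 1 `COc1ccc2occ(CSC(=S)N(C(C)C)C(C)C)c(=O)c2c1` has been tested in a functional assay on LM7 cells (Homo sapiens) for antiproliferative activity, read by MTT assay, with a stated time of 72 h (a higher number here means a weaker inhibitor, a lower number a stronger inhibitor), where compound 1 gives 4700 nM. Among the results shown, that is the only full number. Compound 2 `O=c1c(SC(=S)N2CCCCC2)coc2ccc(Cl)cc12` reaches only a limit of this assay, > 25000 nM, so no number is known for it; this is the limit of > 25000 nM in this assay, at which 1 of the 2 values shown sits. Among the compounds with values here, compound 1 and compound 2 differ in more than one place, so the two results show only that one gave a number and the other did not.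

Compound 3 `COc1ccc2occ(CSC(=S)N3CCCC3)c(=O)c2c1` differs from compound 1 in a single place: pyrrolidin-1-yl in place of diisopropylamino on a thiocarbonyl carbon. Within the data shown here, no measured pair here differs in one place, so no measured step guides the expectation. A smaller amine on the thiocarbonyl carbon is expected to shift potency only modestly, with the step from compound 1 to compound 3 estimated as a 1.5-fold higher number from compound 1 to compound 3 (0.17 log units; within the scatter), barely beyond the usual scatter, toward a weaker inhibitor. Compound 3 is therefore expected to give about 7000 nM in this assay, estimated to lie between 2500 nM and 20000 nM.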

Compound 3, half-maximal inhibitory concentration: 6000 nM
Compound 3: the middle estimate sits 1.2-fold (0.07 log units) above what was measured; low and high end bracket the measured number.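

Within the data shown here, this is the first step in the set that changes one place only, on a thiocarbonyl carbon whose other neighbour is sulfur. In this assay, the swap of open, branched diisopropylamino for the ring of pyrrolidin-1-yl gives a 1.3-fold higher number from compound 1 to compound 3 (0.11 log units; within the scatter) so compound 1 and compound 3 cannot be told apart, and for this pair, closing the amine into a ring with fewer heavy atoms leaves the read-out unchanged. Nothing shown here offers a reason for this result.

Going by these compounds, whether other amines at this place, such as morpholine or dimethylamine, or a group that is no amine at all, such as a longer carbon chain, would give similar numbers remains open. On these data alone, compound 2 gives > 25000 nM as a limit of the assay, not a number, and differs from compound 1 in more than one place, so which of those differences matters also remains unknown.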